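Series notes: removing the ring methyl of compound 2

This account rests on a few compounds, and the source may have more. Where it says the series, first, only, none or still open, it means among the compounds named here.

Measured so far:
- compound 1: `CC(=O)N[C@H]1CCCc2c1cncc2N1Cc2cc(Cl)ccc2C1=O`; in an ADME assay on cells for inhibition of cytochrome P450 11B1, mitochondrial (Homo sapiens), read by HTRF (a higher number here means a weaker inhibitor, a lower number a stronger inhibitor), compound 1 gives 39600 nM
- compound 2: `CC(=O)N[C@@H]1CCCc2c1cncc2N1C(=O)c2ccc(Cl)cc2[C@H]1C`; in this assay compound 2 gives 5140 nM

Compound 2 holds the lower of the two numbers in this assay; the gap to compound 1 lies beyond the scatter, so compound 2 is the stronger inhibitor of the pair.

The next compound is compound 3, `CC(=O)N[C@@H]1CCCc2c1cncc2N1Cc2cc(Cl)ccc2C1=O`. It differs from compound 2 in one place: hydrogen in place of methyl on a saturated ring carbon.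

Within the data shown here, no pair of measured compounds isolates this change, so there is no measured step to lean on. The expectation is that dropping the methyl costs some potency, a step of a 2.3-fold higher number from compound 2 to compound 3 (0.37 log units; beyond the scatter), likely beyond the scatter but not large. Compound 3 is therefore estimated at 12000 nM, with a range from 3000 nM to 50000 nM.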

Compound 3, half-maximal inhibitory concentration: 2330 nM
Compound 3: the middle estimate sits 5.2-fold (0.71 log units) above what was measured; the whole stated range lies above it.
By their numbers in this assay, from the lowest: compound 3; then compound 2; then compound 1.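

In this assay, the methyl on this saturated ring carbon does not add to inhibition: replacing it with hydrogen gives a 2.2-fold lower number from compound 2 to compound 3 (0.34 log units; beyond the scatter), a modest change towards stronger inhibition that lies beyond the scatter. Compound 3 is thus the strongest inhibitor of the three compounds shown. The stereocentre at a saturated ring carbon has a larger effect, with a 17-fold lower number from compound 1 to compound 3 (1.23 log units; beyond the scatter), and this step can be assigned to that stereocentre alone because of one fact: the fact that compounds 1 and 3 differ only in the configuration as drawn.

As far as these compounds go, it remains open whether an ethyl or hydroxymethyl group on the ring carbon would follow the step seen for methyl, and whether the opposite configuration at that carbon would give the same result. From the compounds shown here alone, the effect of methyl in the configuration of compound 1 also remains open.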